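The source may report more compounds than this note shows. Statements on the series, on what has been measured and on what is new or still open speak of the compounds shown alone.

Measured in an ADME assay on BCBL1 cells (Homo sapiens) for cytotoxicity, with a stated time of 7 days; on this read-out lower numbers stand for higher toxicity in this test and higher numbers for lower toxicity in this test:
- compound 1 `CNc1nc(N)nc2c1ncn2/C=C1/CC1(CO)CO`: 67000 nM
- compound 2 `COCCOc1nc(N)nc2c1ncn2/C=C1/CC1(CO)CO`: > 20000 nM (a limit)
- compound 3 `CCCCCCCCSc1nc(N)nc2c1ncn2/C=C1/CC1(CO)CO`: > 20000 nM (a limit)

Compound 3 gives only a limit, > 20000 nM, and so stands at the limit of > 20000 nM in this assay, at which 2 of the 3 values shown sit. It therefore offers no exact number as a starting point.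

The next compound, compound 4 `CC(C)CNc1nc(N)nc2c1ncn2/C=C1/CC1(CO)CO`, has isobutylamino in place of octylsulfanyl on an aromatic carbon. The rest of the molecule stays the same.

Among the compounds with values here, three measured steps touch this position: a step that the limit leaves unreadable from compound 1 to compound 2, a step that the limit leaves unreadable from compound 1 to compound 3 and a step that the two limits leave unreadable from compound 2 to compound 3. None of them has a readable size, so none can say how large a change to expect, or in which direction.

The nearest guide is compound 1, which carries methylamino on the same aromatic carbon and gives 67000 nM. Compound 4 also carries an amino-linked chain, so a value in the same broad region seems reasonable, though the longer isobutylamino group leaves this uncertain.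

The expected step is a step that the limit leaves unreadable from compound 3 to compound 4, an estimate resting on that single comparison. For compound 4 the estimated value is 40000 nM, with an expected range from 12000 nM to 100000 nM.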

Compound 4, half-maximal cytotoxic concentration: > 20000 nM
Compound 4 gave a limit, no number; the forecaster's own chance of this, stated with the estimate: 50%; the middle value is on the limit's open side.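

Within the data shown here, compound 4 gives > 20000 nM as a limit, not a number, so no step linking it to compound 1, compound 2 or compound 3 can be read. It sits with the other limits: the limit of > 20000 nM in this assay, at which 3 of the 4 values shown sit.

In this assay the compounds shown leave open how compound 2, compound 3 and compound 4 compare with one another and with compound 1.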